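This account rests on a few compounds, and the source may have more. Where it says the series, first, only, none or still open, it means among the compounds named here.

Of the compounds shown here, three that share one core have been tested in an assay on CHO cells for displacement of a labelled ligand from adenosine receptor A3 (Homo sapiens), read by scintillation counting, with a stated time of 120 min, tested at 10 uM; a lower number here means less inhibition, a higher number more inhibition at the concentration tested (going by the name of the read-out). Compound 1 `Nc1scc(CN2CCN(c3ccc([N+](=O)[O-])cc3)CC2)c1C(=O)c1ccc(Cl)cc1` gives 2%. Compound 2 `Nc1scc(CN2CCC(c3ccc(Cl)cc3)CC2)c1C(=O)c1ccc(Cl)cc1` gives 6%, and compound 3 `Nc1scc(CN2CCN(c3cccc(F)c3)CC2)c1C(=O)c1cccc(C(F)(F)F)c1` gives 0%. Compound 1 holds the second highest of the three numbers, yet its gaps to compound 3 and to compound 2 both lie within the usual scatter, so no real order among the three can be read. Compound 4 `Nc1scc(CN2CCN(c3cc(F)cc(F)c3)CC2)c1C(=O)c1ccc(Cl)cc1` has not yet been measured. It differs from compound 1 in one place: 3,5-difluorophenyl in place of 4-nitrophenyl on an amine nitrogen in a ring. Among the measured compounds shown here, no step between measured compounds is on hand to show what such a change does. Since every measured number sits low, the step this estimate means, a number 1 percentage points higher from compound 1 to compound 4 (within the scatter), is expected to be none beyond the scatter. Compound 4 is therefore estimated at 3%, between -5% and 12%.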

Compound 4, a percentage reported as inhibition, at one concentration (the size of the read-out at that concentration, not a potency): 2%
Estimate against measurement, compound 4: 1 percentage points above; the range from low to high includes it.
By their numbers in this assay, from the lowest: compounds 3, 1, 4 and 2 (each within the scatter of the next).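

In this assay, 3,5-difluorophenyl in place of 4-nitrophenyl on an amine nitrogen in a ring gives no change at the digits printed from compound 1 to compound 4 (within the scatter). Among the compounds shown here, this is the first step that can be read at this position, and it shows that this swap does not lift inhibition out of the low range at the concentration tested. No measurement shown bears on why the number stays where it is. Still open, as far as these compounds go, is whether a different group on this nitrogen, such as a benzyl group or a pyridine ring, would raise the number. A carboxylic acid or an amine on the phenyl ring is equally untested among the compounds shown.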